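The source may hold more compounds than are shown below. What is called first, only, known or untested is meant among the compounds shown, and "the series" means these compounds.

Measured compounds:
Compound 1, `NS(=O)(=O)NCCC1CCN(c2cc(-c3cccc(Cl)c3)ncn2)CC1`, in a functional assay on M21 cells (Homo sapiens) for antiproliferative activity, read by sulforhodamine B assay, with a stated time of 48 h (on this read-out higher numbers stand for weaker inhibition of growth and lower numbers for stronger inhibition of growth), gives 50700 nM.
Compound 2, `COc1ccccc1-c1cc(N2CCC(CCNS(N)(=O)=O)CC2)ncn1`, in this assay gives 96900 nM.

Among these two numbers in this assay, compound 2 is the one that reads higher, but the only measured step, a 1.9-fold higher number from compound 1 to compound 2 (0.28 log units; within the scatter), lies within the scatter, so on the evidence so far compound 1 and compound 2 cannot be told apart. Compound 3, `NS(=O)(=O)NCCC1CCN(c2cc(-c3ccccc3F)ncn2)CC1`, has not yet been measured. It differs from compound 2 in one place: fluoro in place of methoxy on an aromatic carbon. Going by the values given here, no measured step exchanges methoxy for fluoro at this place, so nothing bears on it directly. Among the compounds with values here, the one step that exists, a 1.9-fold higher number from compound 1 to compound 2 (0.28 log units; within the scatter), replaced one substituted phenyl with another and produced no change beyond the scatter, and that gives no reason to expect a larger effect from this smaller exchange. The expected step is therefore a 1.3-fold lower number from compound 2 to compound 3 (0.11 log units; within the scatter), which amounts to none beyond the scatter. Compound 3 is accordingly estimated at 75000 nM, with a likely range from 30000 nM to 190000 nM.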

Compound 3, concentration for 50% growth inhibition: 81800 nM
The estimate for compound 3 lay 1.1-fold (0.04 log units) below the measured number; measured number inside the range.
By their numbers in this assay, from the lowest: compounds 1, 3 and 2 (each within the scatter of the next).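

In this assay, fluoro in place of methoxy gives a 1.2-fold lower number from compound 2 to compound 3 (0.07 log units; within the scatter). Going by these compounds alone, this exchange, on an aromatic carbon ortho to a large group, removes a group of two heavy atoms with one hydrogen-bond acceptor and puts in a single fluorine atom with none, yet the read-out stays within the scatter, which is the first direct look at this change at this place. The second new comparison, a 1.6-fold higher number from compound 1 to compound 3 (0.21 log units; within the scatter), sets the 2-fluorophenyl against the 3-chlorophenyl and also lies within the scatter, so the 3-chlorophenyl, 2-methoxyphenyl and 2-fluorophenyl compounds cannot be told apart on this read-out, and nothing measured alongside these numbers offers an explanation.

The compounds shown leave open whether a group of a different kind at this place, such as an amine or a carboxylic acid, would move the number beyond the scatter. Within the data shown here, they also leave open whether any change to the shared core would do so, as every step so far concerns the substituted phenyl alone.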